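The source may hold more compounds than are shown below. What is called first, only, known or untested is meant among the compounds shown, and "the series" means these compounds.

Compound 1 `Cc1cnc(NCC2(c3ccccc3)CCC2)c(=O)n1CC(=O)NCc1ccc2c(N)noc2c1`: 8.6. Compound 2 `Cc1cnc(NCC2(c3ccc(F)cc3)CC2)c(=O)n1CC(=O)NCc1ccc2[nH]nc(N)c2c1`: 3.6. Compound 3 `Cc1cnc(NCC2(c3ccccn3)CC2)c(=O)n1CC(=O)NCc1ccc2c(N)noc2c1`: 8.6.

In a physicochemical assay for acid dissociation, compound 3 stands level with compound 1 at the digits shown, the two together the highest of the three, while compound 2 sits far below both; compound 2 differs from compound 3 in more than one place, so its value alone does not isolate either change. Going by the values given here, the only measured step that bears on the present change is no change at the digits printed from compound 1 to compound 3 (within the scatter), and it was flat. Compound 4 `Cc1cnc(NCC2(c3ccc(F)cc3)CC2)c(=O)n1CC(=O)NCc1ccc2c(N)noc2c1` differs from compound 3 by 4-fluorophenyl in place of pyridin-2-yl on a saturated ring carbon. Because no change at the digits printed from compound 1 to compound 3 (within the scatter) left this assay unchanged, no step beyond the scatter is expected: no change at the digits printed from compound 3 to compound 4 (within the scatter). Compound 4 is therefore estimated at 8.6, within 8.1 to 9.1.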

Compound 4, acid dissociation constant: 8.6
Compound 4: middle estimate and measured number agree at the digits printed; measured number inside the range.
By their numbers in this assay, from the lowest: compound 2; then compounds 1, 3 and 4 (each within the scatter of the next).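

In this assay the steps of no change at the digits printed from compound 3 to compound 4 (within the scatter) and no change at the digits printed from compound 1 to compound 4 (within the scatter) show that the number holds when this saturated ring carbon carries 4-fluorophenyl rather than pyridin-2-yl, and that 1-(4-fluorophenyl)cyclopropyl matches 1-phenylcyclobutyl on the chain carbon. Going by these compounds alone, the step of a number 5.00 log units higher from compound 2 to compound 4 (beyond the scatter) gives the first comparison in one place for the group on the saturated chain carbon bound to an amide-type nitrogen, and this is where the number moves. No evidence on the origin of these steps is at hand. As far as these compounds go, whether an amine or a carboxylic acid on that saturated ring carbon would also leave the number level stays open.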